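Methoxy addition across two biaryl cores, antiproliferative read-out

The source may report more compounds than this note shows. Statements on the series, on what has been measured and on what is new or still open speak of the compounds shown alone.

Measured so far:
compound 1 `COc1ccc(/C=C/C(=O)c2ccccc2-c2ccc(OC)c(OC)c2)cc1`: 320 nM
compound 2 `COc1ccc(/C=C/C(=O)c2ccccc2-c2ccc(OC)c(OC)c2)cc1OC`: 2500 nM
compound 3 `COc1ccc(CNC(=O)c2ccccc2-c2ccc(F)cc2)cc1`: > 50000 nM

In a functional assay on CNE-2 cells (Homo sapiens) for antiproliferative activity, read by sulforhodamine B assay, with a stated time of 48 h (on this read-out higher numbers stand for weaker inhibition and lower numbers for stronger inhibition), compound 1 gives 320 nM. The change methoxy in place of hydrogen on an aromatic carbon leads to compound 2, and it gives 2500 nM in this assay, that is a 7.8-fold higher number from compound 1 to compound 2 (0.89 log units; beyond the scatter). Compound 3 carries a different core, and the difference between the two cores is not broken down here. For compound 3 only a limit of this assay is known, > 50000 nM, and no number. For the measured compounds named here, compound 4 `COc1ccc(CNC(=O)c2ccccc2-c2ccc(F)cc2)cc1OC` remains to be measured; it arises from compound 3 by methoxy in place of hydrogen on an aromatic carbon, which is the same change as the one from compound 1 to compound 2, with the same surroundings of the place. The measured step points to a higher number after this change. Compound 4 is expected to give 80000 nM in this assay, because compound 3 already sits at the limit of > 50000 nM in this assay, at which 1 of the 3 values shown sits. The step that this estimate means is a step that the limit leaves unreadable from compound 3 to compound 4, expected most likely to stay out of the numerical range of the assay.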

Compound 4, half-maximal inhibitory concentration: > 50000 nM
Compound 4: only a limit was reported (the forecaster's own chance of this, stated with the estimate: 85%); the middle value does not contradict the limit.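

In this assay compound 4 gives > 50000 nM which is a limit and not a number, and compound 3 sits at the same limit, so no step can be read from compound 3 to compound 4: the limit of > 50000 nM in this assay, at which 2 of the 4 values shown sit.

Going by these compounds, whether methoxy in place of hydrogen on an aromatic carbon shifts the core of compound 3 as it shifts the core of compound 1 stays open.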